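The compounds below may be only part of what the source reports. "The series", "measured", "known", "first", "only" and "open" are said of these compounds alone.

Measured compounds in a functional assay on HeLa cells (Homo sapiens) for antiproliferative activity, read by MTT assay; on this read-out higher numbers stand for weaker inhibition and lower numbers for stronger inhibition:

Compound 1, `CN1CCN(c2ccc(Nc3ncc(/N=C/c4ccc(C(F)(F)F)cc4)c(NC4CCCC4)n3)cc2)CC1`, gives > 100000 nM, a limit of the assay.
Compound 2, `CCOC(=O)/C=N/c1cnc(Nc2ccc(N3CCN(C)CC3)cc2)nc1NC(C)C`, gives 11500 nM.
Compound 3, `CC(C)Nc1nc(Nc2ccc(N3CCN(C)CC3)cc2)ncc1/N=C/c1ccccc1`, gives > 100000 nM, a limit of the assay.

Compound 3 stands at the upper limit of this assay, with no number recorded for it. Going by the values given here, the only step measured is an at least 8.6-fold higher number from compound 2 to compound 3 (0.93 log units; beyond the scatter), which moved compound 3 onto the limit where compound 1 also sits (the limit of > 100000 nM in this assay, at which 2 of the 3 values shown sit).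

Compound 4, `CC(C)Nc1nc(Nc2ccc(N3CCN(C)CC3)cc2)ncc1/N=C/c1ccc(C(F)(F)F)cc1`, differs from compound 3 by trifluoromethyl in place of hydrogen on an aromatic carbon. Among the compounds with values here, no measured step tests this change directly. Compound 1 already carries the trifluoromethyl group on its phenyl ring together with a different amine on the shared core, and compound 1 sits at the limit of this assay. With compound 3 itself at the limit, the expectation is that compound 4 is reported at the limit as well, giving no step beyond the scatter, a step that the limit leaves unreadable from compound 3 to compound 4. The estimate for compound 4 in this assay is 150000 nM, within the range 50000 nM to 500000 nM.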

Compound 4, half-maximal inhibitory concentration: > 100000 nM
Compound 4: only a limit was reported; the forecaster's own chance of this, stated with the estimate: 75%; the middle value lies beyond the limit too.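

In this assay compound 4 gives > 100000 nM, which is a limit of the assay and not a number. With 4-(trifluoromethyl)phenyl in place of ethoxycarbonyl on the carbon with a double bond to nitrogen, the change reads as an at least 8.6-fold higher number from compound 2 to compound 4 (0.93 log units; beyond the scatter), so both phenyl and 4-(trifluoromethyl)phenyl at this position now end at the limit. The steps from compound 3 and from compound 1 to compound 4 cannot be read, which leaves the trifluoromethyl change and the isopropyl-for-cyclopentyl change without a size, and the series crowds at one end of the read-out: the limit of > 100000 nM in this assay, at which 3 of the 4 values shown sit.

Going by these compounds alone, compound 2, at 11500 nM, is the only compound here with a number. As far as these compounds go, whether an amide or a carboxylic acid in place of its ethoxycarbonyl would keep a measurable value remains open.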